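The source may hold more compounds than are shown below. What is called first, only, known or untested is meant among the compounds shown, and "the series" means these compounds.

Measured so far: compound 1 `O=C(CCCN1CCC(n2cnc3ccccc32)CC1)c1ccc(F)cc1`, > 3 mg/kg; compound 2 `O=C(CCCN1CCC(n2c(C(F)(F)F)nc3ccccc32)CC1)c1ccc(F)cc1`, "not determined" (no result reported).

In a functional assay on the whole organism (strain STD-ddY) with Mus musculus as the target, with stated times of 1 h and 24 h (on this read-out higher numbers stand for an effect only at larger amounts of compound and lower numbers for an effect already at smaller amounts), compound 1 gives > 3 mg/kg, which is a limit of the assay and not a number. In this assay, within the data shown here, compound 2 gives "not determined" (no result reported), so it stands on no number, and the only value is the limit of > 3 mg/kg in this assay, at which 1 of the 2 values shown sits. Compound 3 `CSc1nc2ccccc2n1C1CCN(CCCC(=O)c2ccc(F)cc2)CC1` differs from compound 2 in one place: methylsulfanyl in place of trifluoromethyl on an aromatic carbon. No measured step of this kind is shown, so the size or direction of any change in this assay cannot be read from the data, and none beyond the scatter is expected. Compound 3 is expected to give about 5 mg/kg, with a range from 1 mg/kg to 30 mg/kg.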

Compound 3, dose for half-maximal effect: 0.68 mg/kg
Estimate against measurement, compound 3: 7.4-fold (0.87 log units) above, outside the stated range (below it).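

In this assay, methylsulfanyl in place of hydrogen on this aromatic carbon between two ring nitrogen atoms gives an at least 4.4-fold lower number from compound 1 to compound 3 (0.64 log units; beyond the scatter). Among these compounds, this is the first sign that a group at this position goes with a lower number, and the step lies beyond the scatter. Compound 1 stands at a limit and not at a number, so the full size of the step stays open: the limit of > 3 mg/kg in this assay, at which 1 of the 3 values shown sits.

The step from trifluoromethyl to methylsulfanyl cannot be read, as compound 2 has no result. On these data alone, whether an amine or ethylsulfanyl on this carbon would match compound 3 remains open.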